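The compounds below may be only part of what the source reports. "The series", "measured", "known", "first", "only" and "open" are said of these compounds alone.

Of the compounds shown here, three built on one shared core have been measured in a functional assay on A549 cells (Homo sapiens) for antiproliferative activity, read by MTT assay, with a stated time of 72 h; on this read-out higher numbers stand for weaker inhibition and lower numbers for stronger inhibition. Compound 1 `O=C(Nc1ccc(Oc2ccnc3[nH]ccc23)c(F)c1)c1cc2cccnc2n(-c2ccc(Cl)cc2)c1=O` gives 110 nM in this assay. Compound 2 `Cn1ccc2c(Oc3ccc(NC(=O)c4cc5cccnc5n(-c5ccc(Cl)cc5)c4=O)cc3)ccnc21` gives 630 nM in this assay. Compound 3 `Cn1ccc2c(Oc3ccc(NC(=O)c4cc5cccnc5n(-c5ccccc5)c4=O)cc3F)ccnc21` gives 430 nM in this assay. Among these three numbers compound 3 stands second highest: its number and that of compound 2 lie within the usual scatter of each other, so nothing separates them, whereas compound 1 gives a clearly lower number, beyond the scatter, meaning compound 1 inhibits cell growth more strongly than compound 3.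

Compound 4 `Cn1ccc2c(Oc3ccc(NC(=O)c4cc5cccnc5n(-c5ccc(Cl)cc5)c4=O)cc3F)ccnc21` has not yet been measured. It differs from compound 3 in one place: chloro in place of hydrogen on an aromatic carbon, on an aromatic carbon of a six-membered aromatic ring of carbon only, para to a large group; the same difference, cut one bond further out, reads phenyl to 4-chlorophenyl. For the measured compounds named here, no pair of measured compounds differs by this change alone, so its size cannot be read off directly. Compound 1 and compound 2 both carry the 4-chlorophenyl, one with a number clearly below that of compound 3 and one within the scatter of it, so no consistent pull in one direction shows. The expected step of a 1.3-fold lower number from compound 3 to compound 4 (0.13 log units; within the scatter) is therefore small, likely within the scatter. Compound 4 is expected to give about 320 nM, with a range from 110 nM to 950 nM.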

Compound 4, half-maximal inhibitory concentration: 350 nM
For compound 4 the middle estimate is 1.1-fold (0.04 log units) below the measured one; the measured number falls inside the stated range.
By their numbers in this assay, from the lowest: compound 1; then compounds 4, 3 and 2 (each within the scatter of the next).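

In this assay, chloro in place of hydrogen on the carbon-only aromatic ring, para to a large group, gives a 1.2-fold lower number from compound 3 to compound 4 (0.09 log units; within the scatter), so this first direct reading of the change does not separate phenyl from 4-chlorophenyl. For the compounds shown here, the change that brings in fluoro, the other one that can now be read on its own, gives a 1.8-fold lower number from compound 2 to compound 4 (0.26 log units; within the scatter) and also stays inside the noise, whereas methyl in place of hydrogen on an aromatic nitrogen gives a 3.2-fold higher number from compound 1 to compound 4 (0.50 log units; beyond the scatter), the only step of the three that clears it and so the one change here that tells two compounds apart. Nothing available explains any of these three steps.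

From the compounds shown here alone, with only hydrogen and chloro seen at this position, it remains open whether a different group there, such as methoxy, an amine or a carboxylic acid, would move the number. Also open, going by these compounds, is whether the chloro step would stay this small with hydrogen rather than methyl on the aromatic nitrogen, as in compound 1.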